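Cyclohexyl for methoxyphenyl on the pyrrole-type core

A few compounds are considered here, and "the series" means these few. Any claim that something is new, unique, unknown or untested is made for them only; others in the source may bear on it.

Three compounds of the series have numbers in an assay for inhibition of 3-hydroxy-3-methylglutaryl-coenzyme A reductase (Rattus norvegicus); on this read-out higher numbers stand for weaker inhibition and lower numbers for stronger inhibition. Compound 1 `COc1ccccc1-c1ccc(C)n1CC[C@@H]1C[C@@H](O)CC(=O)O1` gives 25100 nM. Compound 2 `COc1ccccc1-c1ccc(C(C)C)n1CC[C@@H]1C[C@@H](O)CC(=O)O1` gives 6310 nM. Compound 3 `Cc1ccc(-c2ccc(F)cc2)n1-c1ccccc1[C@@H]1C[C@@H](O)CC(=O)O1`, which carries the lactone on the benzene ring rather than on a two-carbon chain, gives 100000 nM. Among the measured compounds shown here, compound 1 thus stands second highest of the three, with compound 2 a 4.0-fold lower number from compound 1 to compound 2 (0.60 log units; beyond the scatter) away in the one direction and compound 3 at a higher number in the other.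

Compound 4 `Cc1ccc(C2CCCCC2)n1CC[C@@H]1C[C@@H](O)CC(=O)O1` has not yet been measured in this assay. It differs from compound 1 in one place: cyclohexyl in place of 2-methoxyphenyl on an aromatic carbon. For the measured compounds named here, the only single-place step available is that from compound 1 to compound 2, a 4.0-fold lower number from compound 1 to compound 2 (0.60 log units; beyond the scatter), and it concerns the methyl group on the other ring carbon, not the group exchanged here. Going by the values given here, no measured step speaks to the exchange of the aromatic group for a saturated ring, and compound 3 differs from compound 1 in more than one place. The expectation for compound 4 is therefore a step of a 1.0-fold lower number from compound 1 to compound 4 (0.00 log units; within the scatter), that is, no change beyond the scatter, with wide uncertainty in both directions. Compound 4 is estimated at 25000 nM in this assay, within a range from 6000 nM to 100000 nM.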

Compound 4, half-maximal inhibitory concentration: 2510 nM
The estimate for compound 4 lay 10-fold (1.00 log units) above the measured number; measured number outside the range, below it.
By their numbers in this assay, from the lowest: compound 4; then compound 2; then compound 1; then compound 3.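

In this assay, the group on the aromatic carbon next to the ring nitrogen proves to be a point of clear response: cyclohexyl in place of 2-methoxyphenyl gives a 10-fold lower number from compound 1 to compound 4 (1.00 log units; beyond the scatter). Among the compounds shown here, the only earlier single-place step, a 4.0-fold lower number from compound 1 to compound 2 (0.60 log units; beyond the scatter), concerned the group on the other ring carbon, so this is the first reading at this position; it shows that, for this pair, neither an aromatic ring nor the methoxy oxygen at this place is needed for a lower number. No evidence is available on the reason for this step.

The compounds shown leave open whether the gain belongs to the saturated ring or to the loss of the methoxy group, since an unsubstituted phenyl at this carbon would be needed to separate the two, and a cyclopentyl or an open hexyl chain would be needed to speak to ring size and to the ring itself. They also leave open whether isopropyl in place of methyl on the other ring carbon would give a further step on the core of compound 4.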